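Replacing the Benzoyl Phenyl with Aminomethyl on a Shared Core

The source may report more compounds than this note shows. Statements on the series, on what has been measured and on what is new or still open speak of the compounds shown alone.

Compound 2 `COc1nc(N2CCN(C)CC2)nc(OC)c1Sc1cccc(NC(=O)c2ccccc2)c1` stands as the stronger of the two measured compounds in a functional assay on SK-BR-3 cells (Homo sapiens) for cytotoxicity, read by resazurin assay, with a stated time of 72 h (a higher number here means a weaker inhibitor of growth, a lower number a stronger inhibitor of growth), where compound 2 gives 8 uM. Among the compounds with values here, its only measured neighbour, compound 1 `CCC(=O)Nc1cccc(Sc2c(OC)nc(N3CCN(C)CC3)nc2OC)c1`, differs by an ethyl in place of the phenyl on the carbonyl carbon; in this assay compound 1 gives 55 uM. Within the data shown here, the one measured step, a 6.9-fold lower number from compound 1 to compound 2 (0.84 log units; beyond the scatter), shows that the phenyl on that carbonyl carbon is worth a good deal on this core. Compound 3 `COc1nc(N2CCN(C)CC2)nc(OC)c1Sc1cccc(NC(=O)CN)c1` changes the same position again, this time away from phenyl: aminomethyl in place of phenyl on a carbonyl carbon. Among the measured compounds shown here, no measured pair speaks to aminomethyl itself, but the single step that touches this carbonyl carbon went the other way, from a small group to phenyl, and gained. The author therefore expects the number for compound 3 to rise beyond the scatter, with the step of a 6.3-fold higher number from compound 2 to compound 3 (0.80 log units; beyond the scatter) expected to be of roughly the size of that measured step, in the reverse direction. For compound 3 the estimate is 50 uM, within a range of 15 uM to 150 uM.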

Compound 3, concentration for growth inhibition (reported as GI): 25 uM
The estimate for compound 3 lay 2.0-fold (0.30 log units) above the measured number; low and high end bracket the measured number.
By their numbers in this assay, from the lowest: compound 2; then compound 3; then compound 1.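

Compound 3 shows that the carbonyl carbon does not have to carry phenyl for the number to fall below that of compound 1, though giving up the phenyl still costs something, with a 3.1-fold higher number from compound 2 to compound 3 (0.49 log units; beyond the scatter). The more telling comparison is with the ethyl amide: amino in place of methyl on a saturated chain carbon bound to a carbonyl carbon gives a 2.2-fold lower number from compound 1 to compound 3 (0.34 log units; beyond the scatter), so a single change at the end of this short chain moves the number beyond the scatter, and neither of the two ringless groups has reached phenyl, leaving compound 2 with the lowest number of the three. Why the amino group or the phenyl has this effect cannot be said, as no measurement on the mechanism is available here.

Still open, from the compounds shown here alone, is whether the gain belongs to the amine itself or would also come with a hydroxyl in its place, as in hydroxymethyl. Equally open, going by these compounds, is whether a longer chain ending in an amine, or an amine carried on the phenyl of compound 2, would bring the two gains together on the shared core.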